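Bromo for chloro on the shared core

The source may hold more compounds than are shown below. What is called first, only, known or untested is meant among the compounds shown, and "the series" means these compounds.

Among the measured compounds shown here, in an ADME assay on MDCK cells (Canis lupus familiaris) for cytotoxicity, read by MTT assay, with a stated time of 24 h (on this read-out higher numbers stand for lower toxicity in this test and lower numbers for higher toxicity in this test), compound 3 `Cc1cc(CNS(=O)(=O)c2ccc(Cl)cc2)c(C)s1` gives 52900 nM as the only true number so far. Compound 1 `Cc1cc(CNS(=O)(=O)c2ccc(C#N)cc2)c(C)s1` sits at > 217000 nM as a limit of the assay, not a number. For compound 2 `Cc1cc(CNS(=O)(=O)c2ccc(F)cc2)c(C)s1` the entry reads "not determined" (no result reported) and no number exists. Compound 4 `Cc1cc(CNS(=O)(=O)c2ccc(Br)cc2)c(C)s1` differs from compound 3 by bromo in place of chloro on an aromatic carbon in one change, bromo in place of chloro on an aromatic carbon. For the measured compounds named here, the one measured step bearing on this is an at least 4.1-fold lower number from compound 1 to compound 3 (0.61 log units; beyond the scatter) with compound 1 entering it through the limit of > 217000 nM in this assay, at which 1 of the 3 values shown sits, as a limit. That step involves no bromo and gives no direction, so the expectation stays with compound 3 at 52900 nM and no shift beyond the scatter in this assay is foreseen. The expected change is a 1.2-fold lower number from compound 3 to compound 4 (0.07 log units; within the scatter) and no larger. Compound 4 is estimated at 45000 nM with an expected range from 18000 nM to 120000 nM around it.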

Compound 4, half-maximal cytotoxic concentration: 56400 nM
For compound 4 the middle estimate is 1.3-fold (0.10 log units) below the measured one, within the range that was stated.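

In this assay, bromo in place of chloro on this aromatic carbon, para to a large group, gives a 1.1-fold higher number from compound 3 to compound 4 (0.03 log units; within the scatter), so the two groups cannot be told apart here. Bromo in place of cyano gives an at least 3.8-fold lower number from compound 1 to compound 4 (0.58 log units; beyond the scatter), which shows that a second group, not chloro alone, stands on the same side of the cyano compound. This step rests on the value for compound 1, which is a limit of the assay and not a number: the limit of > 217000 nM in this assay, at which 1 of the 4 values shown sits. On these data alone, what an amine or a carboxylic acid on this aromatic carbon would give stays open.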